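The source may report more compounds than this note shows. Statements on the series, on what has been measured and on what is new or still open speak of the compounds shown alone.

Compound 1 `O=C(Nc1ccc(Nc2ncnc3c2OCCN3)cc1)Nc1ccc(Cl)c(C(F)(F)F)c1` gives 188 nM in an assay on isolated protein for inhibition of proto-oncogene tyrosine-protein kinase receptor Ret variant V804M (Homo sapiens), read by 33P incorporation, with stated times of 15 min and 40 min; on this read-out lower numbers stand for stronger inhibition and higher numbers for weaker inhibition.
Compound 2 `O=C(Nc1ccc(Cl)cc1)Nc1ccc(Nc2ncnc3c2OCCN3)cc1` gives 2280 nM in this assay.
Compound 3 `O=C(Nc1ccc(Nc2ncnc3c2OCCN3)cc1)Nc1ccc(C(F)(F)F)cc1` gives 276 nM in this assay.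

Compound 3 holds the second highest of these three numbers; its value and that of compound 1 lie within the scatter of each other, while it sits far from compound 2, as an 8.3-fold lower number from compound 2 to compound 3 (0.92 log units; beyond the scatter) shows. Compound 4 `COc1cccc(NC(=O)Nc2ccc(Nc3ncnc4c3OCCN4)cc2)c1` differs from compound 3 by 3-methoxyphenyl in place of 4-(trifluoromethyl)phenyl on an amide-type nitrogen. Going by the values given here, two measured steps bear on this: a 12-fold higher number from compound 1 to compound 2 (1.08 log units; beyond the scatter) shows that losing the trifluoromethyl costs much, and an 8.3-fold lower number from compound 2 to compound 3 (0.92 log units; beyond the scatter) shows the gain from putting it in. Since the trifluoromethyl is again removed, compound 4 is expected to show a step of a 5.4-fold higher number from compound 3 to compound 4 (0.74 log units; beyond the scatter) in this assay. Compound 4 is therefore estimated at 1500 nM, with a range from 400 nM to 5000 nM.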

Compound 4, half-maximal inhibitory concentration: 5290 nM
Compound 4: middle estimate off by 3.5-fold (0.55 log units), on the low side; measured number outside the range, above it.
By their numbers in this assay, from the lowest: compounds 1 and 3 (each within the scatter of the next); then compound 2; then compound 4.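

The change to 3-methoxyphenyl on the amide-type nitrogen brings a 19-fold higher number from compound 3 to compound 4 (1.28 log units; beyond the scatter) in this assay and shows that this position does not accept every replacement of 4-(trifluoromethyl)phenyl. The step of a 2.3-fold higher number from compound 2 to compound 4 (0.37 log units; beyond the scatter) is modest but beyond the scatter, and it places 3-methoxyphenyl behind 4-chlorophenyl as well. The group and its place on the ring change together here, and the compounds shown cannot separate the two, nor tell how a phenyl carrying an amine or a carboxylic acid would fare. No measurement given here accounts for the size of these steps.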